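The source may report more compounds than this note shows. Statements on the series, on what has been measured and on what is new or still open speak of the compounds shown alone.

Measured in a functional assay on SEM cells (Homo sapiens) for cytotoxicity, with a stated time of 72 h; a lower number here means that less compound is needed, a higher number that more compound is needed for the effect:
Compound 1 `C=C[C@@](C)(/C=C/c1ccc(Nc2ccc(OC)cc2)cc1)CCC=C(C)C`: > 36600 nM, a limit.
Compound 2 `C=C[C@@](C)(/C=C/c1ccc(Nc2cc(F)cc(F)c2)cc1)CCC=C(C)C`: > 36600 nM, a limit.

Compound 2 has no number in this assay, only the limit > 36600 nM. Within the data shown here, compound 1, the only other compound measured, also has only a limit, and the record so far is the limit of > 36600 nM in this assay, at which 2 of the 2 values shown sit.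

Compound 3 `C=C[C@@](C)(/C=C/c1ccc(Nc2cc(F)c(F)cc2F)cc1)CCC=C(C)C` differs from compound 2 in one group: 2,4,5-trifluorophenyl in place of 3,5-difluorophenyl on a nitrogen on an aromatic ring. Among the measured compounds shown here, the one measured step, a step that the two limits leave unreadable from compound 1 to compound 2, also exchanges the group on that nitrogen, but it gives no size to carry over. No step beyond the scatter is therefore expected in this assay, and no direction is favoured. The expected move is a step that the limit leaves unreadable from compound 2 to compound 3. Compound 3 is estimated at 40000 nM, with an expected range of 18000 nM to 80000 nM. A report of only a limit would be no surprise.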

Compound 3, half-maximal effective concentration: > 36600 nM
Compound 3: no number, only a limit (the forecaster's own chance of this, stated with the estimate: 75%); the middle value lies beyond the limit too.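

In this assay the steps among compound 1, compound 2 and compound 3 cannot be read, since all three carry only a limit: the limit of > 36600 nM in this assay, at which 3 of the 3 values shown sit. The compounds shown leave open whether any group on that nitrogen gives a readable value, and how far these three groups differ.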